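Aryl ketone variation on the thioether chain

The source may hold more compounds than are shown below. What is called first, only, known or untested is meant among the compounds shown, and "the series" means these compounds.

Compound 1 `C#CCSc1nnc(-c2cc(OC)c(OC)c(OC)c2)n1N1C(=O)c2ccccc2C1=O` in a functional assay on PC-3M cells (Homo sapiens) for cytotoxicity, read by MTT assay, with a stated time of 48 h (on this read-out higher numbers stand for weaker inhibition and lower numbers for stronger inhibition), gives only a limit of the assay, > 200000 nM. Compound 2 `COc1cc(-c2nnc(SCC(=O)c3ccc(C)cc3)n2N2C(=O)c3ccccc3C2=O)cc(OC)c1OC` gives 11700 nM in this assay. Compound 3 `COc1cc(-c2nnc(SCC(=O)c3ccccc3C)n2N2C(=O)c3ccccc3C2=O)cc(OC)c1OC` stands at the limit of this assay, > 200000 nM. Two of the three results therefore rest on (the limit of > 200000 nM in this assay, at which 2 of the 3 values shown sit). The steps read an at least 17-fold lower number from compound 1 to compound 2 (1.23 log units; beyond the scatter); a step that the two limits leave unreadable from compound 1 to compound 3; an at least 17-fold higher number from compound 2 to compound 3 (1.23 log units; beyond the scatter). Compound 4 `COc1cc(-c2nnc(SCC(=O)c3ccc(F)c(F)c3)n2N2C(=O)c3ccccc3C2=O)cc(OC)c1OC` is not yet measured; it differs from compound 3 in that (3,4-difluorophenyl in place of 2-methylphenyl on a carbonyl carbon). Among the measured compounds shown here, the only measured step that alters the aryl group on this carbonyl carbon is an at least 17-fold higher number from compound 2 to compound 3 (1.23 log units; beyond the scatter), a large one, which shows that a change on this ring can move the number far. For compound 4 the expected step is an at least 4.0-fold lower number from compound 3 to compound 4 (0.60 log units; beyond the scatter), with a value estimated near 50000 nM, in the range 8000 nM to 200000 nM.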

Compound 4, half-maximal inhibitory concentration: 163000 nM
Compound 4: middle estimate off by 3.3-fold (0.51 log units), on the low side; low and high end bracket the measured number.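

In this assay, 3,4-difluorophenyl on this carbonyl carbon gives a 14-fold higher number from compound 2 to compound 4 (1.14 log units; beyond the scatter), so of the aryl groups shown, only 4-methylphenyl stands clearly apart. Against the two compounds held at the assay limit, the readings are only floors that lie within the scatter: an at least 1.2-fold lower number from compound 3 to compound 4 (0.08 log units; that floor lies within the scatter) and an at least 1.2-fold lower number from compound 1 to compound 4 (0.08 log units; that floor lies within the scatter). Compound 4 therefore gives a measured number but no readable separation from compound 1 or compound 3.

As far as these compounds go, what 4-fluorophenyl, 4-methoxyphenyl or 4-aminophenyl would give on this carbonyl carbon stays open. So does whether any group here can bring the number below that of compound 2.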